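The source may hold more compounds than are shown below. What is called first, only, known or untested is meant among the compounds shown, and "the series" means these compounds.

In a functional assay on NCI-H460 cells (Homo sapiens) for cytotoxicity, read by MTT assay, with a stated time of 72 h (a lower number here means a stronger inhibitor, a higher number a weaker inhibitor), compound 1 (`COc1ccc(/C=C2\CNC/C(=C\c3ccc(OC)c(OC)c3)C2=O)cc1OC`) gives 6400 nM as its half-maximal inhibitory concentration. Compound 2 (`CCCN1C/C(=C\c2ccc(OC)c(OC)c2)C(=O)/C(=C/c2ccc(OC)c(OC)c2)C1`) gives 4100 nM and so stands within the scatter of compound 1. Compound 3 (`COc1ccc(/C=C2\CN(C)C/C(=C\c3ccc(OC)c(OC)c3)C2=O)cc1OC`) has no value yet. The change from compound 2 to compound 3 is hydrogen in place of ethyl on a saturated chain carbon bound to an amine nitrogen in a ring, which, cut one bond further out, reads propyl to methyl. Among the measured compounds shown here, one measured step bears on it, a 1.6-fold lower number from compound 1 to compound 2 (0.19 log units; within the scatter) for propyl in place of hydrogen on an amine nitrogen in a ring, and that step lies within the scatter. Compound 3 has methyl on that nitrogen, where compound 1 has hydrogen and compound 2 has propyl. No step beyond the scatter is therefore expected in this assay for this change. The estimated move is small (a 1.2-fold higher number from compound 2 to compound 3 (0.09 log units; within the scatter)). Compound 3 is expected at 5000 nM with a range from 2300 nM to 11000 nM in this estimate.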

Compound 3, half-maximal inhibitory concentration: 3100 nM
Compound 3: middle estimate off by 1.6-fold (0.21 log units), on the high side; low and high end bracket the measured number.
By their numbers in this assay, from the lowest: compounds 3, 2 and 1 (each within the scatter of the next, the first and the last beyond it).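

In this assay, among the compounds shown here, methyl on the amine nitrogen in the ring gives the first step at this position that clears the scatter, a modest one (a 2.1-fold lower number from compound 1 to compound 3 (0.31 log units; beyond the scatter)). Methyl and propyl on this nitrogen are not separated (a 1.3-fold lower number from compound 2 to compound 3 (0.12 log units; within the scatter)), and propyl also stays within the scatter of hydrogen (a 1.6-fold lower number from compound 1 to compound 2 (0.19 log units; within the scatter)), so the three compounds give no firm order by chain length. Nothing measured here accounts for these numbers.

Still open, as far as these compounds go, is whether a longer chain such as butyl, a benzyl group or an acetyl group on this nitrogen would move the number beyond the scatter of compound 3. With only hydrogen, methyl and propyl at this position, the effect of the substituent rests on one modest step in a single cell line.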